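A few compounds are considered here, and "the series" means these few. Any claim that something is new, unique, unknown or untested is made for them only; others in the source may bear on it.

Measured so far in a physicochemical assay for lipophilicity, read by HPLC, in phosphate buffer, measured as chromatographic lipophilicity, at pH 7.4; on this read-out higher numbers stand for higher lipophilicity and lower numbers for lower lipophilicity:
compound 1, `COc1ccc2nc(C)cc(OC3CCN(c4ccccc4)C3=O)c2c1`: 4.99
compound 2, `COc1ccc2nc(C)cc(OCC(=O)Nc3ccccc3)c2c1`: 4.28
compound 3, `COc1ccc2nc(C)cc(OCC(=O)Nc3cc(OC)c(OC)c(OC)c3)c2c1`: 3.95

All three compounds share the same core and differ only in the group attached through the oxygen on that core. Among the three numbers in this assay, compound 2 stands second highest. Its nearest neighbour is compound 3, whose value is lower by more than the usual scatter of this measurement, and its furthest neighbour is compound 1, whose value is higher, again by more than the usual scatter.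

The next compound to be measured is compound 4, `COc1ccc2nc(C)cc(OCC(=O)NC3CONC3=O)c2c1`. It differs from compound 2 in one place:
a group of 6 heavy atoms (3 carbon, 1 nitrogen, 2 oxygen; one five-membered non-aromatic ring with 2 hetero atoms) in place of a group of 6 heavy atoms (6 carbon; one six-membered aromatic ring of carbon only), on an amide-type nitrogen
In plain terms, the flat carbon-only ring on the amide-type nitrogen is swapped for a small five-membered non-aromatic ring that brings a hydrogen-bond donor and two hydrogen-bond acceptors along.

Among the compounds with values here, no step between measured compounds is available as a guide for a change of this kind. Still, among the compounds at hand, the one with the most oxygen and nitrogen in its side group, compound 3, sits lowest, and compound 4 goes much further in that direction. A downward step well beyond the scatter is therefore expected, a number 1.98 log units lower from compound 2 to compound 4 (beyond the scatter). Compound 4 is expected to give about 2.3 in this assay, with a likely range from 1.6 to 3.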

Compound 4, distribution coefficient: 0.79
Compound 4: the middle estimate sits 1.51 log units above what was measured; the whole stated range lies above it.
By their numbers in this assay, from the lowest: compound 4; then compound 3; then compound 2; then compound 1.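

In this assay, swapping the group on the amide-type nitrogen gives a number 3.49 log units lower from compound 2 to compound 4 (beyond the scatter) and places compound 4 far below the other compounds, so this single position can move the read-out over a wide span. Phenyl and the new five-membered non-aromatic ring with 2 hetero atoms both count 6 heavy atoms, so this large step comes with no change in heavy-atom count; what changes is the kind of atoms and ring, along with the hydrogen-bond donor and acceptors that enter. No measurement at hand gives a reason for the size of this step.

Several things change together in this one swap, and the two compounds cannot show how much of the step belongs to the loss of the aromatic ring, the ring size, or the added nitrogen and oxygen atoms. A cyclohexyl group or a cyclopentyl group on the same nitrogen would separate the ring's carbon framework from its hetero atoms, and a pyridyl group would test a single ring nitrogen while keeping an aromatic ring.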